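Thiourea-linked anilinoquinazoline sulfonamides: antiproliferative read-out

A few compounds are considered here, and "the series" means these few. Any claim that something is new, unique, unknown or untested is made for them only; others in the source may bear on it.

Of the compounds shown here, two carry numbers so far. Compound 1 `COc1cc2ncnc(Nc3ccc(C(F)(F)F)cc3)c2cc1OCCCCC(=O)Nc1ccc(S(N)(=O)=O)cc1` gives 16900 nM in a functional assay on A-431 cells (Homo sapiens) for antiproliferative activity, read by MTT assay, with a stated time of 72 h; on this read-out higher numbers stand for weaker inhibition and lower numbers for stronger inhibition. Among the measured compounds shown here, compound 2 `NS(=O)(=O)c1ccc(NC(=S)Nc2ccc3ncnc(Nc4ccc(F)c(Br)c4)c3c2)cc1` gives 18200 nM in this assay, the higher of the two numbers, with compound 1 as its only neighbour; the gap between them lies within the scatter, so the two read as equivalent. For the measured compounds named here, no step between compounds that differ in one place is available, so nothing in the measured pair anchors the size of the next change. Compound 3 `CCc1ccc(Nc2ncnc3ccc(NC(=S)Nc4ccc(S(N)(=O)=O)cc4)cc23)cc1` differs from compound 2 by 4-ethylphenyl in place of 3-bromo-4-fluorophenyl on a nitrogen on an aromatic ring. With compound 2 already at 18200 nM, the step from compound 2 to compound 3 is expected to be small and toward a somewhat higher number, a 1.4-fold higher number from compound 2 to compound 3 (0.14 log units; within the scatter), or none beyond the scatter. Compound 3 is estimated at 25000 nM, within 8000 nM to 80000 nM.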

Compound 3, half-maximal inhibitory concentration: 38400 nM
Compound 3: the middle estimate sits 1.5-fold (0.19 log units) below what was measured; the range from low to high includes it.
By their numbers in this assay, from the lowest: compounds 1 and 2 (each within the scatter of the next); then compound 3.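

The aryl group on a nitrogen on an aromatic ring is not silent in this assay: 4-ethylphenyl in place of 3-bromo-4-fluorophenyl gives a 2.1-fold higher number from compound 2 to compound 3 (0.32 log units; beyond the scatter), a modest step and the only one so far that can be read between compounds differing in one place. Both groups hold 8 heavy atoms and one six-membered aromatic ring of carbon only, so the step goes with an all-carbon group replacing a group bearing bromine and fluorine, not with a change in heavy-atom count. Nothing measured here bears on why the number moves.

This single step cannot separate the loss of bromine, the loss of fluorine and the gain of ethyl. Going by these compounds, whether a plain phenyl or a chlorophenyl on the same nitrogen stays near compound 2 at 18200 nM remains open.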